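Demethylation in nitrate-bearing cinnamates: what compound 4 should give

This account rests on a few compounds, and the source may have more. Where it says the series, first, only, none or still open, it means among the compounds named here.

Four nitrate ester cinnamates are compared in a functional assay on HeLa cells (Homo sapiens) for cytotoxicity, read by resazurin assay, with a stated time of 72 h; on this read-out lower numbers stand for stronger inhibition and higher numbers for weaker inhibition. Compound 1 `COc1cc(/C=C/C(=O)OCCCO[N+](=O)[O-])ccc1OCCCO[N+](=O)[O-]` gives 3620 nM. Compound 2 `O=C(/C=C/c1ccc(OCCCCCCO[N+](=O)[O-])c(O)c1)OCCCCCCO[N+](=O)[O-]` gives 1350 nM. Compound 3 `COc1cc(/C=C/C(=O)OCCCCCCO[N+](=O)[O-])ccc1OCCCCCCO[N+](=O)[O-]` gives only a limit of the assay, > 50000 nM. Compound 1 and compound 3 differ in their chains; the difference between the two cores is not broken down here. The change hydrogen in place of methyl on an oxygen on an aromatic ring yields an at least 37-fold lower number from compound 3 to compound 2 (1.56 log units; beyond the scatter). This figure is a floor rather than a measured ratio because of the limit of > 50000 nM in this assay, at which 1 of the 3 values shown sits.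

Compound 4 `O=C(/C=C/c1ccc(OCCCO[N+](=O)[O-])c(O)c1)OCCCO[N+](=O)[O-]` has not yet been measured in this assay. It differs from compound 1 by hydrogen in place of methyl on an oxygen on an aromatic ring, the same change as between compound 3 and compound 2, at the same place. Resting on that step and on the value of compound 1 3620 nM, compound 4 is expected to give 800 nM, with a likely span from 250 nM to 3000 nM. The estimate means an expected step of a 4.5-fold lower number from compound 1 to compound 4 (0.66 log units; beyond the scatter), smaller than the floor seen earlier. Compound 1 already gives 3620 nM and starts well inside the measurable range.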

Compound 4, half-maximal inhibitory concentration: > 50000 nM
Compound 4: only a limit was reported; the forecaster's own chance of this, stated with the estimate: 3%; middle value at least 62-fold (1.79 log units) away from the limit.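

In this assay compound 4 gives > 50000 nM as a limit of the assay and not a number. Methoxy to hydroxy on the chains of compound 1 gives an at least 13-fold higher number from compound 1 to compound 4 (1.14 log units; beyond the scatter) and so does not carry over from the chains of compound 3 and compound 2, where the same change ran the opposite way: the same change on two cores in this assay, an at least 37-fold lower number (1.56 log units; beyond the scatter) from compound 3 to compound 2 and an at least 13-fold higher number (1.14 log units; beyond the scatter) from compound 1 to compound 4, at least 510-fold (2.70 log units) apart, beyond the scatter of two such steps. Both steps are floors, so they show the direction of the change on each core but not its true size, and they do not show what sets the two cores apart: the limit of > 50000 nM in this assay, at which 2 of the 4 values shown sit.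

On these data alone, whether an amine or a carboxylic acid in place of the hydroxy group, or a still longer chain, would bring the core of compound 4 back into the measurable range remains open. As far as these compounds go, it also remains open how far compound 3 and compound 4 lie from that range, and whether the reversal extends to any other chain.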